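Replacing the Aryl Hydroxyl with Chlorine in a Cytotoxicity Series

The source may report more compounds than this note shows. Statements on the series, on what has been measured and on what is new or still open speak of the compounds shown alone.

Compound 1 `C/C(=N\NC(=O)/C(C#N)=C/c1ccc(O)cc1)c1c(O)c2ccc(O)cc2oc1=O` is the weaker of the two measured compounds: in a functional assay on NRK-49F cells (Rattus norvegicus) for cytotoxicity, read by MTT assay, with a stated time of 24 h (on this read-out higher numbers stand for weaker inhibition and lower numbers for stronger inhibition), compound 1 gives 61300 nM, while compound 2 `COc1ccc(/C=C(\C#N)C(=O)N/N=C(\C)c2c(O)c3ccc(O)cc3oc2=O)cc1OC` gives 45300 nM, a gap that is a 1.4-fold lower number from compound 1 to compound 2 (0.13 log units; within the scatter). Compound 3 `C/C(=N\NC(=O)/C(C#N)=C/c1ccccc1Cl)c1c(O)c2ccc(O)cc2oc1=O` differs from compound 1 only by 2-chlorophenyl in place of 4-hydroxyphenyl on a double-bonded chain carbon bound to a double-bonded chain carbon. Among the compounds with values here, the one step that bears on this change, the swap of the same ring in a 1.4-fold lower number from compound 1 to compound 2 (0.13 log units; within the scatter), stayed within the scatter, so no shift beyond the scatter is expected for compound 3, estimated as a 1.1-fold lower number from compound 1 to compound 3 (0.05 log units; within the scatter). Compound 3 is therefore estimated at 55000 nM, with a range of 25000 nM to 120000 nM.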

Compound 3, half-maximal inhibitory concentration: 55900 nM
Compound 3: middle estimate off by 1.0-fold (0.01 log units), on the low side; low and high end bracket the measured number.
By their numbers in this assay, from the lowest: compounds 2, 3 and 1 (each within the scatter of the next).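

In this assay, the step of a 1.1-fold lower number from compound 1 to compound 3 (0.04 log units; within the scatter) shows that on a double-bonded chain carbon bound to a double-bonded chain carbon, 2-chlorophenyl, with no hydrogen-bond donor, cannot be told apart from 4-hydroxyphenyl. The step of a 1.2-fold higher number from compound 2 to compound 3 (0.09 log units; within the scatter) also stays within the scatter, so all three aryl groups shown give equivalent numbers at this place. Nothing available explains this result. On these data alone, whether a ring bearing an amine or a carboxylic acid would move the number beyond the scatter remains open.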